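Two Ring Stereocentres Inverted in a Peroxide Acid

A few compounds are considered here, and "the series" means these few. Any claim that something is new, unique, unknown or untested is made for them only; others in the source may bear on it.

Measured so far in a functional assay on IGROV-1 cells (Homo sapiens) for inhibition; on this read-out higher numbers stand for weaker inhibition of growth and lower numbers for stronger inhibition of growth:
compound 1 `C=C1CCCC(C)(C)C1CC[C@]1(C)CC[C@@H]([C@@H](C)C(=O)O)OO1` gives 1730 nM
compound 2 `C=C1CCCC(C)(C)C1CC[C@]1(C)CC[C@H]([C@@H](C)C(=O)OC)OO1` gives 500 nM
compound 3 `C=C1CCC[C@H]2[C@](C)(CC[C@]3(C)CC[C@@H]([C@@H](C)C(=O)O)OO3)[C@@H](C)CC[C@]12C` gives 100 nM

Compound 1 stands at the highest number of the three in this assay, which on this read-out means the weakest inhibition of growth shown here. Its nearest neighbour is compound 2, whose number is lower by a margin beyond the usual scatter; compound 3 lies furthest away, lower again by a margin well beyond the scatter. No two of these compounds differ in only one place, so no single-point step can be read from the measured set.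

Compound 4 `C=C1CCCC(C)(C)C1CC[C@@]1(C)CC[C@H]([C@@H](C)C(=O)O)OO1` is the next compound to be measured. Relative to compound 1, (the two compounds have the same atoms and bonds; at least one stereo element is drawn with a configuration in one of them and without one in the other: 2 of 4 stereo elements differ; a stereocentre at a saturated ring carbon is drawn R in compound 1 and S in compound 4; a stereocentre at a saturated ring carbon is drawn S in compound 1 and R in compound 4). Among the compounds with values here, the measured compounds offer no step in which only stereocentres change, so there is nothing within the set that says how large such a change should be in this assay. With the atoms and bonds unchanged, the step from compound 1 to compound 4 is expected to be a 1.2-fold higher number from compound 1 to compound 4 (0.06 log units; within the scatter), that is, no change that clearly exceeds the scatter. Compound 4 is therefore estimated at 2000 nM, within a range from 700 nM to 6000 nM.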

Compound 4, concentration for 50% growth inhibition: 630 nM
Beside the measured number, compound 4's estimate is 3.2-fold (0.50 log units) above it; the measured number lies below the stated range.
By their numbers in this assay, from the lowest: compound 3; then compounds 2 and 4 (each within the scatter of the next); then compound 1.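

In this assay, within the data shown here, this is the first step in the set where only stereocentres change, and inverting the two at saturated ring carbons, with all atoms and bonds kept, gives a 2.7-fold lower number from compound 1 to compound 4 (0.44 log units; beyond the scatter). The earlier compounds shown here could not show that the spatial arrangement at these two ring carbons matters by itself on this read-out; here it does, modestly, and the change runs towards stronger inhibition of growth. The reading of this step as a purely stereochemical comparison carries one qualification: the fact that one of compounds 1 and 4 is drawn with a defined configuration and the other without, at the place where they differ.

Both stereocentres change together, so the compounds shown leave open whether one of them accounts for the step or both contribute, and whether the same inversion would have a similar effect in the methyl ester or in the larger core of compound 3. They also leave open how the inverted arrangement of compound 4 would behave with an amide or a longer chain in place of the carboxylic acid.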